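Chloro to Fluoro on the Phenethyl Ether Tail

The source may report more compounds than this note shows. Statements on the series, on what has been measured and on what is new or still open speak of the compounds shown alone.

Compound 1 `COc1ccc(CCOc2ccc(CSc3c(Cl)cccc3Cl)nc2/C=C/C(=O)O)cc1` gives 1.2 nM in an assay on isolated protein for binding affinity to leukotriene B4 receptor 1 (Homo sapiens); on this read-out higher numbers stand for weaker inhibition and lower numbers for stronger inhibition. Compound 2 `O=C(O)/C=C/c1nc(CSc2c(Cl)cccc2Cl)ccc1OCCc1ccc(Cl)cc1` gives 1.3 nM in this assay. The step of a 1.1-fold higher number from compound 1 to compound 2 (0.03 log units; within the scatter) left the number essentially unchanged, so compound 2 stands within the scatter of compound 1. Compound 3 `O=C(O)/C=C/c1nc(CSc2c(Cl)cccc2Cl)ccc1OCCc1ccc(F)cc1` differs from compound 2 by fluoro in place of chloro on an aromatic carbon. Going by the values given here, the only step that bears on this is the one from compound 1 to compound 2, which swapped a group at the same place and stayed within the scatter, so no step beyond the scatter is expected in this assay. Compound 3 is therefore estimated at 1.6 nM, between 0.6 nM and 4.5 nM. The expected step is a 1.2-fold higher number from compound 2 to compound 3 (0.09 log units; within the scatter).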

Compound 3, inhibition constant: 1.5 nM
Compound 3: middle estimate off by 1.1-fold (0.03 log units), on the high side, and the stated range covers the measured number.
By their numbers in this assay, from the lowest: compounds 1, 2 and 3 (each within the scatter of the next).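

In this assay a second swap at this place, a 1.2-fold higher number from compound 2 to compound 3 (0.06 log units; within the scatter), lies within the scatter, and the direct comparison of the two ends of the series, a 1.3-fold higher number from compound 1 to compound 3 (0.10 log units; within the scatter), does too. Methoxy, chloro and fluoro, each para to a large group, therefore cannot be told apart at this position in these three compounds. Nothing available explains why these groups give such similar numbers. Still open, going by these compounds, is how this position responds to a group of a different kind, such as an amine or a carboxylic acid. Also open, on these data alone, is what plain hydrogen would give here.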